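Neopentyl to isopropyl on the carbonyl of compound 3

The source may report more compounds than this note shows. Statements on the series, on what has been measured and on what is new or still open speak of the compounds shown alone.

Measured compounds:
compound 1 `COc1cc(C(=O)O)ccc1OCCCCOc1ccc(C(=O)CC(C)C)c(O)c1C` — 73.9%
compound 2 `Cc1c(OCCCCOc2ccc(C(=O)O)cc2Cl)ccc(C(=O)CC2CCCC2)c1O` — 27.4%
compound 3 `Cc1c(OCCCCOc2ccc(C(=O)CC(C)(C)C)c(O)c2C)cccc1C(=O)O` — 109%

In an assay on HEK293 cells for positive allosteric modulation of metabotropic glutamate receptor 3 (Rattus norvegicus), read by thallium flux, with a stated time of 2.5 min (on this read-out lower numbers stand for smaller maximal responses and higher numbers for larger maximal responses), compound 3 gives 109%, the highest of the three numbers. Compound 1 gives 73.9%, a gap beyond the scatter, and compound 2 gives 27.4%, the widest gap. Compound 1 and compound 2 each differ from compound 3 in more than one place, so no single change can be read from those pairs.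

Compound 4 `Cc1c(OCCCCOc2ccc(C(=O)C(C)C)c(O)c2C)cccc1C(=O)O` is not yet measured. It differs from compound 3 in one place: isopropyl in place of neopentyl on a carbonyl carbon. The ketone side chain is shortened by two carbons while everything else, the shared core and the butylene linker, is kept.

Going by the values given here, no measured pair isolates this change. Among the compounds with values here, the only guide is that compound 1, which carries a smaller isobutyl group on the carbonyl carbon though its acid-bearing ring also differs, gives 73.9%, below the number of compound 3. The expected step from compound 3 to compound 4 in this assay is therefore a moderate fall, a number 24 percentage points lower from compound 3 to compound 4 (beyond the scatter), with wide uncertainty. Compound 4 is estimated at 85%, within 50% to 115%.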

Compound 4, largest response reached (reported as percent of maximum), in percent of the reference or control that the assay uses: 27.1%
For compound 4 the middle estimate is 57.9 percentage points above the measured one; the measured number lies below the stated range.
By their numbers in this assay, from the lowest: compounds 4 and 2 (each within the scatter of the next); then compound 1; then compound 3.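

In this assay, the group on the carbonyl carbon now has a step of its own: with the shared core and the butylene linker kept, isopropyl in place of neopentyl gives a number 81.9 percentage points lower from compound 3 to compound 4 (beyond the scatter) as a large change. The maximal response at this position therefore depends heavily on the group carried there, which compound 1 and compound 2 could not isolate, each differing from compound 3 in more than one place; here the exchange of 5 heavy atoms for 3 heavy atoms alone accounts for the whole step, with no ring, hydrogen-bond donor, hydrogen-bond acceptor or net charge entering or leaving. No measurement shown gives a reason for this step.

Going by these compounds alone, with only two groups compared on this core, the shape of the dependence at the carbonyl carbon stays open, including whether tert-butyl or cyclopropylmethyl would hold the response of compound 3 or lose it as isopropyl does. Also open, from the compounds shown here alone, is whether a longer chain, such as n-hexyl, would raise the response further or reduce it.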